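The compounds below may be only part of what the source reports. "The series", "measured", "known", "first", "only" and "open" are said of these compounds alone.

Measured so far:
Compound 1 `Oc1ccc(/C=C2\CCN=C2c2cccnc2)c(O)c1`, in an assay for displacement of a labelled ligand from Nicotinic acetylcholine receptor alpha8 subunit (Periplaneta americana), read by scintillation counting, with a stated time of 2 h, at 24 degrees C (on this read-out lower numbers stand for stronger inhibition and higher numbers for weaker inhibition), compound 1 gives 120 nM.
Compound 2 `CN(C)c1ccc(/C=C/C=C2\CCN=C2c2cccnc2)cc1`, in this assay compound 2 gives 2070 nM.

For the measured compounds named here, of these two numbers, the one for compound 2 is the higher, so compound 2 is the weaker binder of the pair, and the gap to compound 1 lies beyond the scatter. Compound 3 `C(=C/c1ccccc1)\C=C1/CCN=C1c1cccnc1` differs from compound 2 by one change: hydrogen in place of dimethylamino on an aromatic carbon. Going by the values given here, no measured pair shows what such a change does here, so the expected step from compound 2 to compound 3 is a 1.2-fold higher number from compound 2 to compound 3 (0.08 log units; within the scatter), a small one that need not exceed the scatter. For compound 3 the estimate in this assay is 2500 nM, between 900 nM and 7000 nM.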

Compound 3, half-maximal inhibitory concentration: 3520 nM
For compound 3 the middle estimate is 1.4-fold (0.15 log units) below the measured one, and the stated range covers the measured number.
By their numbers in this assay, from the lowest: compound 1; then compounds 2 and 3 (each within the scatter of the next).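

In this assay, replacing the dimethylamino group on the aromatic carbon with hydrogen gives a 1.7-fold higher number from compound 2 to compound 3 (0.23 log units; within the scatter). For the compounds shown here, this is the first single-change comparison, and it shows that compound 2 and compound 3 cannot be told apart here, with or without the dimethylamino group at this position. No data on hand explain this result.

From the compounds shown here alone, whether a methoxy group, a fluorine atom or a carboxylic acid at this position would move the number beyond the scatter remains open. Also open is which of the several differences between compound 1 and compound 2 accounts for the gap between them.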